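Replacing a Methyl on the Ring Amine with an Oxazole Carbonyl

The compounds below may be only part of what the source reports. "The series", "measured", "known", "first", "only" and "open" are said of these compounds alone.

Of the compounds shown here, three have been measured in a physicochemical assay for lipophilicity, read by HPLC, measured as chromatographic lipophilicity, at pH 7.4; on this read-out lower numbers stand for lower lipophilicity and higher numbers for higher lipophilicity. Compound 1, `O=C(C1CCN(c2cccnn2)CC1)N1N=CC[C@H]1c1ccccc1`, gives 3.4. Compound 2, `CN1CCC(C(=O)N2N=CCC2c2ccccc2)CC1`, gives 1.1, the lowest of the three numbers. Compound 3, `N#Cc1cnc(N2CCC(C(=O)N3N=CC[C@H]3c3cc(F)cc(F)c3)CC2)cn1`, gives 5.2, the highest. The nearest number to compound 2 is that of compound 1, which lies higher by a margin beyond the usual scatter, and the number of compound 3 lies higher still, again beyond the scatter.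

The step followed here goes from compound 2 to compound 4, `O=C(c1cocn1)N1CCC(C(=O)N2N=CCC2c2ccccc2)CC1`, which has not yet been measured in this assay. The change is (1,3-oxazol-4-yl)carbonyl in place of methyl on an amine nitrogen in a ring. Going by the values given here, no step between measured compounds in this set matches this change, so its size must be judged from the whole set. Among the compounds with values here, the larger group that enters brings a ring and several acceptors in place of a single carbon, and the only compounds with a larger group on that nitrogen, compound 1 and compound 3, read well above compound 2. Compound 4 is therefore expected to read higher than compound 2, with the step from a number 1.60 log units higher from compound 2 to compound 4 (beyond the scatter) estimated as clearly beyond the scatter. The estimate for compound 4 in this assay is 2.7, with a range from 1.9 to 3.5.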

Compound 4, distribution coefficient: 2.9
The estimate for compound 4 lay 0.20 log units below the measured number, within the range that was stated.
By their numbers in this assay, from the lowest: compound 2; then compound 4; then compound 1; then compound 3.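

In this assay, this amine nitrogen in the six-membered ring now has a measured step of its own: a number 1.80 log units higher from compound 2 to compound 4 (beyond the scatter), a large change that lies beyond the usual scatter. Going by these compounds alone, the earlier compounds differed from each other in more than one place, so this is the first reading in which (1,3-oxazol-4-yl)carbonyl replaces methyl on that nitrogen while the rest of the molecule stays the same, and the number can be tied to this one change. The step still treats the entering group as a single unit, with the carbonyl and the five-membered aromatic ring arriving together, and nothing in the data gives a reason for the rise.

The compounds shown leave open how the step would divide between those two parts, which an acetyl group, with a carbonyl but no ring, or an oxazol-4-yl group attached directly to the nitrogen, with a ring but no carbonyl, could help to show. From the compounds shown here alone, how a small chain such as ethyl, or a group carrying a carboxylic acid, would read on this nitrogen also remains open.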